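The source may hold more compounds than are shown below. What is called first, only, known or untested is meant among the compounds shown, and "the series" means these compounds.

Working notes on the series. Among the compounds with values here, compound 1 `Cc1cccc(C)c1Oc1ccc([N+](=O)[O-])c(Nc2ccc(C#N)cc2)c1` carries the only full number: in an ADME assay on H9 cells (Homo sapiens) for cytotoxicity, read by XTT assay, with a stated time of 6 days (a higher number here means that more compound is tolerated, a lower number that less compound is tolerated), compound 1 gives 69600 nM. Compound 2 `Cc1cc(C)c(Oc2cc(Nc3ccc(C#N)cc3)c([N+](=O)[O-])cc2[N+](=O)[O-])c(C)c1` does not give a number; in this assay compound 2 gives > 59800 nM, which is a limit of the assay. Compound 2 therefore sits at the limit of > 59800 nM in this assay, at which 1 of the 2 values shown sits. Compound 3 `Cc1cc(Br)cc(C)c1Oc1ccc([N+](=O)[O-])c(Nc2ccc(C#N)cc2)c1` differs from compound 1 by bromo in place of hydrogen on an aromatic carbon. Within the data shown here, no measured pair covers this change, so in this assay a step from compound 1 to compound 3 no larger than the scatter is expected, with the estimate a 1.2-fold lower number from compound 1 to compound 3 (0.06 log units; within the scatter). Compound 3 is expected to give about 60000 nM, within 30000 nM to 120000 nM.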

Compound 3, half-maximal cytotoxic concentration: > 57000 nM
Compound 3: no number, only a limit; the forecaster's own chance of this, stated with the estimate: 40%; the middle value is on the limit's open side.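

In this assay compound 3 gives > 57000 nM, which is a limit of the assay. Within the data shown here, no step from compound 1 to compound 3 can be read. The compounds shown leave open whether bromo in place of hydrogen on an aromatic carbon shifts the number in this assay at all.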